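The source may hold more compounds than are shown below. What is called first, only, known or untested is meant among the compounds shown, and "the series" means these compounds.

Measured so far:
compound 1, `CCCS(=O)(=O)Nc1ccc(F)c(C(=O)c2n[nH]c3ncc(-c4ccccc4C)cc23)c1F`: 7%
compound 2, `CCCS(=O)(=O)Nc1ccc(F)c(C(=O)c2n[nH]c3ncc(-c4cc(Cl)cc(Cl)c4)cc23)c1F`: 73%
compound 3, `CCCS(=O)(=O)Nc1ccc(F)c(C(=O)c2n[nH]c3ncc(-c4ccc(Cl)c(Cl)c4)cc23)c1F`: 45%

In an assay for binding affinity to dual specificity mitogen-activated protein kinase kinase 4 (Homo sapiens), read by KINOMEscan, tested at 100 nM (on this read-out higher numbers stand for a weaker effect at the one concentration tested and lower numbers for a stronger effect), compound 3 stands second highest of the three: a number 28 percentage points lower from compound 2 to compound 3 (beyond the scatter), while a number 38 percentage points higher from compound 1 to compound 3 (beyond the scatter). Compound 4, `CCCS(=O)(=O)Nc1ccc(F)c(C(=O)c2n[nH]c3ncc(-c4ccc(NS(C)(=O)=O)cc4)cc23)c1F`, is not yet measured. Its change from compound 3: 4-(methanesulfonamido)phenyl in place of 3,4-dichlorophenyl on an aromatic carbon. Going by the values given here, the steps that bear on it are the other exchanges of the same aryl group, a number 66 percentage points higher from compound 1 to compound 2 (beyond the scatter) and a number 38 percentage points higher from compound 1 to compound 3 (beyond the scatter), both large, showing that this position moves the read-out strongly. Among the compounds with values here, no measured step brings in a methanesulfonamido group, so the direction of the step is open. A step to compound 4 of a number 10 percentage points lower from compound 3 to compound 4 (within the scatter) is expected, with wide uncertainty. Compound 4 is estimated at 35%, range 5% to 85%.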

Compound 4, a percentage reported as activity, at one concentration (the size of the read-out at that concentration, not a potency): 0.85%
Compound 4: the middle estimate sits 34.2 percentage points above what was measured, outside the stated range (below it).
By their numbers in this assay, from the lowest: compounds 4 and 1 (each within the scatter of the next); then compound 3; then compound 2.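

In this assay, the 4-(methanesulfonamido)phenyl group gives a number 44.2 percentage points lower from compound 3 to compound 4 (beyond the scatter) and a number 72.2 percentage points lower from compound 2 to compound 4 (beyond the scatter) as a step away from the dichlorophenyl groups. With a number 6.2 percentage points lower from compound 1 to compound 4 (within the scatter) as the third step, a strong effect at this position is not tied to 2-methylphenyl but is shared by a larger group with 1 hydrogen-bond donor and 2 hydrogen-bond acceptors. Nothing measured here explains these steps.

Still open, going by these compounds, is whether unsubstituted phenyl would read with compound 1 and compound 4 or with compound 2 and compound 3. An amine or carboxylic acid in place of the methanesulfonamido group is also untested in these data.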